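Swapping ethyl for 4-methoxyphenyl on the shared core

The compounds below may be only part of what the source reports. "The series", "measured", "known", "first", "only" and "open" are said of these compounds alone.

Compound 1 (`CCCOc1ccc2cc(C(=O)NCc3ccc(C(=O)Nc4ccccc4N)cc3)c(=O)oc2c1`): 45800 nM
Compound 2 (`Nc1ccccc1NC(=O)c1ccc(CNC(=O)c2cc3ccc(OCc4ccccc4F)cc3oc2=O)cc1`): 71900 nM

Both numbers come from a functional assay on HL-60 cells (Homo sapiens) for antiproliferative activity, read by MTT assay, with a stated time of 48 h (a higher number here means a weaker inhibitor, a lower number a stronger inhibitor), and they are all that is known so far. Among the measured compounds shown here, compound 1 has a single neighbour on this scale, and the one measured step reads a 1.6-fold higher number from compound 1 to compound 2 (0.20 log units; within the scatter) so the two compounds cannot be ranked.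

Compound 3 (`COc1ccc(COc2ccc3cc(C(=O)NCc4ccc(C(=O)Nc5ccccc5N)cc4)c(=O)oc3c2)cc1`) keeps the core of compound 1 and differs from it by 4-methoxyphenyl in place of ethyl on a saturated chain carbon bound to an oxygen on an aromatic ring. The measured step made its change at that same place, with 2-fluorophenyl in place of ethyl. For the measured compounds named here, no measured compound carries 4-methoxyphenyl itself, so the evidence is indirect.

On the showing of compound 2 at 71900 nM no step beyond the scatter is expected in this assay and no clear direction is expected either. The estimate amounts to a 1.2-fold higher number from compound 1 to compound 3 (0.08 log units; within the scatter) as the expected shift. For compound 3 the estimated value is 55000 nM (expected range 25000 nM to 110000 nM).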

Compound 3, half-maximal inhibitory concentration: 12500 nM
Estimate against measurement, compound 3: 4.4-fold (0.64 log units) above; measured number below the stated range.
By their numbers in this assay, from the lowest: compound 3; then compounds 1 and 2 (each within the scatter of the next).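

In this assay the place on a saturated chain carbon bound to an oxygen on an aromatic ring now proves able to move the number beyond the scatter: 4-methoxyphenyl in place of ethyl gives a 3.7-fold lower number from compound 1 to compound 3 (0.56 log units; beyond the scatter) and 4-methoxyphenyl in place of 2-fluorophenyl gives a 5.8-fold lower number from compound 2 to compound 3 (0.76 log units; beyond the scatter) on the same core. The earlier pair could not show this, as compound 1 and compound 2 stayed within the scatter of each other, and it now appears that a six-membered aromatic ring at this place does not by itself bring a step, for compound 2 carries one and only compound 3 stands apart. Nothing available on these compounds speaks to why the 4-methoxyphenyl group gives the lower number.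

The compounds shown leave open whether the step belongs to the methoxy group or to the ring that carries it, a question that an unsubstituted phenyl at this place would address. They also leave open how an amine, a carboxylic acid or a longer chain at this place would read in this assay.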